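Series around a shared core, cytotoxicity readings

The source may report more compounds than this note shows. Statements on the series, on what has been measured and on what is new or still open speak of the compounds shown alone.

Measured so far:
compound 1 `C#CCSc1nnc(CC)n1N1C(=O)c2ccccc2C1=O` — > 200000 nM
compound 2 `CCc1nnc(SCC(=O)c2ccc(Cl)cc2)n1N1C(=O)c2ccccc2C1=O` — > 200000 nM
compound 3 `C#CCSc1nnc(-c2cc(OC)c(OC)c(OC)c2)n1N1C(=O)c2ccccc2C1=O` — > 200000 nM

Compound 1 is `C#CCSc1nnc(CC)n1N1C(=O)c2ccccc2C1=O`. In a functional assay on MKN-45 cells (Homo sapiens) for cytotoxicity, read by MTT assay, with a stated time of 48 h (a higher number here means a weaker inhibitor, a lower number a stronger inhibitor), compound 1 gives > 200000 nM, which is a limit of the assay and not a number. Compound 2 is `CCc1nnc(SCC(=O)c2ccc(Cl)cc2)n1N1C(=O)c2ccccc2C1=O`. In this assay compound 2 gives > 200000 nM, again a limit. The change from compound 1 to compound 2 is (4-chlorophenyl)carbonyl in place of ethynyl on a saturated chain carbon bound to a sulfur, and its step in this assay is a step that the two limits leave unreadable from compound 1 to compound 2, so the size of the step is not readable, because of the limit of > 200000 nM in this assay, at which 3 of the 3 values shown sit.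

Compound 3 is `C#CCSc1nnc(-c2cc(OC)c(OC)c(OC)c2)n1N1C(=O)c2ccccc2C1=O`. In this assay compound 3 gives > 200000 nM, also a limit. The difference between the core of compound 1 and the core of compound 3 is not broken down here.

Compound 4, still to be measured, is `COc1cc(-c2nnc(SCC(=O)c3ccc(Cl)cc3)n2N2C(=O)c3ccccc3C2=O)cc(OC)c1OC`. It differs from compound 3 by (4-chlorophenyl)carbonyl in place of ethynyl on a saturated chain carbon bound to a sulfur, the same change, at the same place, as from compound 1 to compound 2. Since all three measured values sit at a limit, the step of a number no higher from compound 3 to compound 4 (the limit leaves the size open) in this assay is estimated as an unreadable one, resting on the step from compound 1 to compound 2 being a step that the two limits leave unreadable from compound 1 to compound 2 and on (the limit of > 200000 nM in this assay, at which 3 of the 3 values shown sit). Compound 4 is therefore expected to give about 200000 nM in this assay, with a range from 100000 nM to 500000 nM, most likely reported as a limit.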

Compound 4, half-maximal inhibitory concentration: 26600 nM
Compound 4: middle estimate off by 7.5-fold (0.88 log units), on the high side; measured number below the stated range.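

In this assay, (4-chlorophenyl)carbonyl in place of ethynyl on a saturated chain carbon bound to a sulfur gives an at least 7.5-fold lower number from compound 3 to compound 4 (0.87 log units; beyond the scatter), and 3,4,5-trimethoxyphenyl in place of ethyl on an aromatic carbon gives an at least 7.5-fold lower number from compound 2 to compound 4 (0.87 log units; beyond the scatter). From the compounds shown here alone, compound 3 gives > 200000 nM, which is a limit and not a number, so the first of these steps has a lower bound only and its true size stays open. The same change on the core of compound 1 cannot be read, so the notes show a measurable number only where the two groups stand together in compound 4 and do not show that the change carries from one core to the other, because the other values all sit at a limit: the limit of > 200000 nM in this assay, at which 3 of the 4 values shown sit.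

Among the compounds shown here, compound 4 is the only compound here with a number, so the series gives no reading of how much the chlorine of the (4-chlorophenyl)carbonyl group or the methoxy groups of the 3,4,5-trimethoxyphenyl group contribute. Also open, going by these compounds, is what an amine or a carboxylic acid in place of the (4-chlorophenyl)carbonyl, or a longer chain in place of ethyl, would give in this assay.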